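Shortening the chain to an aminomethyl-bearing benzyl group

The compounds below may be only part of what the source reports. "The series", "measured", "known", "first", "only" and "open" are said of these compounds alone.

For the measured compounds named here, compound 2 `c1ccc2c(c1)CN[C@@H](CN(CCCCNC1CCNCC1)[C@H]1CCCc3cccnc31)C2` is, in a functional assay on cells for antagonist activity at C-X-C chemokine receptor type 4 (Homo sapiens), read by fluorescence and calcium flux, with stated times of 25 min and 90 s (a higher number here means a weaker inhibitor, a lower number a stronger inhibitor), the weaker of the two compounds with a number so far, at 63.4 nM. Going by the values given here, its nearest measured neighbour is compound 1 `c1ccc(CNCCCCN(C[C@H]2Cc3ccccc3CN2)[C@H]2CCCc3cccnc32)cc1`, which in this assay gives 20.1 nM; the only measured step is a 3.2-fold higher number from compound 1 to compound 2 (0.50 log units; beyond the scatter), a modest loss when the distal aromatic ring gives way to a saturated nitrogen ring.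

Compound 3 `NCc1cccc(CN(C[C@H]2Cc3ccccc3CN2)[C@H]2CCCc3cccnc32)c1` takes a different route from compound 2: a group of 8 heavy atoms (7 carbon, 1 nitrogen; one six-membered aromatic ring of carbon only) in place of a group of 10 heavy atoms (8 carbon, 2 nitrogen; one six-membered non-aromatic ring with 1 hetero atom), on a saturated chain carbon bound to an amine nitrogen. The long chain with its saturated ring is replaced by a short aromatic group carrying an aminomethyl substituent, so an aromatic ring returns near the amine nitrogen of the core, as in compound 1, though with a shorter spacing and an added basic amine.

Among the compounds with values here, no step matches this change directly. Within the data shown here, the step of a 3.2-fold higher number from compound 1 to compound 2 (0.50 log units; beyond the scatter) is the only guide; it suggests that restoring an aromatic ring may recover part of the loss, but the changed chain length cuts against a confident transfer. Compound 3 is therefore expected to land between compound 1 and compound 2, at 30 nM (range 8 nM to 110 nM), a step of a 2.1-fold lower number from compound 2 to compound 3 (0.32 log units; beyond the scatter).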

Compound 3, half-maximal inhibitory concentration: 292 nM
Compound 3: the middle estimate sits 9.7-fold (0.99 log units) below what was measured; measured number above the stated range.
By their numbers in this assay, from the lowest: compound 1; then compound 2; then compound 3.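

In this assay, the place on a saturated chain carbon bound to an amine nitrogen proves sensitive to the group it carries: 3-(aminomethyl)phenyl gives a 4.6-fold higher number from compound 2 to compound 3 (0.66 log units; beyond the scatter) and a 15-fold higher number from compound 1 to compound 3 (1.16 log units; beyond the scatter), the latter a large step. An aromatic ring at this place does not by itself keep the number low, since compound 1 and compound 3 both carry one at different spacing, yet compound 3 also has a higher number than compound 2, whose group holds a non-aromatic ring. Both steps change chain length and ring type together, so the shorter 3-(aminomethyl)phenyl group marks a loss at this place but does not separate those two changes, and nothing measured accounts for the loss.

Going by these compounds, how a plain benzyl group or a 4-aminobutyl chain would read at this place remains open, and either would help to separate the ring from the length. Also open, on these data alone, is whether a longer chain ending in the same aminomethyl-bearing phenyl ring would return the number towards that of compound 1.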